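The source may hold more compounds than are shown below. What is called first, only, known or untested is meant among the compounds shown, and "the series" means these compounds.

Measured so far:
compound 1, `CCCOc1cc(C)c(-c2cccc(CNc3ccc(OCC(=O)O)c(F)c3)c2)c(C)c1` — 38.7 nM
compound 2, `CCOc1ccc(-c2cccc(CNc3ccc(OCC(=O)O)c(F)c3)c2)c(C)c1` — 11.6 nM

In a functional assay on CHO cells for agonist activity at Free fatty acid receptor 1 (Homo sapiens), read by FLIPR and calcium flux (on this read-out lower numbers stand for an effect already at smaller amounts and higher numbers for an effect only at larger amounts of compound), compound 2 gives the lower of the two numbers: compound 1, its nearest neighbour, gives a higher number, and that gap lies beyond the usual scatter of repeated measurements. The two differ in more than one place, so their values say nothing about any single change on its own.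

Compound 3, `CCCOc1ccc(-c2cccc(CNc3ccc(OCC(=O)O)c(F)c3)c2)c(C)c1`, has not yet been measured. It differs from compound 2 by methyl in place of hydrogen on a saturated chain carbon, two bonds along the chain from an oxygen on an aromatic ring. For the measured compounds named here, no pair of measured compounds shows this change alone, so the expectation rests on compound 2 alone. Lengthening a short chain by one carbon is usually a small step; the number is estimated to stay close to that of compound 2, perhaps slightly higher, with the expected step from compound 2 to compound 3 being a 1.4-fold higher number from compound 2 to compound 3 (0.14 log units; within the scatter). Compound 3 is therefore expected to give about 16 nM, in a range from 6 nM to 45 nM.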

Compound 3, half-maximal effective concentration: 41.3 nM
Compound 3: the middle estimate sits 2.6-fold (0.41 log units) below what was measured; measured number inside the range.
By their numbers in this assay, from the lowest: compound 2; then compounds 1 and 3 (each within the scatter of the next).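

Going from ethoxy to propoxy gives a 3.6-fold higher number from compound 2 to compound 3 (0.55 log units; beyond the scatter) in this assay and is the first single change read here, showing that one added methyl at this chain carbon is enough to separate two compounds beyond the scatter. Hydrogen in place of methyl on an aromatic carbon gives a 1.1-fold higher number from compound 1 to compound 3 (0.03 log units; within the scatter), so with the propoxy chain in place, the numbers do not tell these two compounds apart. Nothing available here explains why the chain change matters while the aromatic change does not.

On these data alone, whether the trend with chain length extends to a shorter methoxy or a longer butoxy chain remains open. So does whether the aromatic methyl would also make no clear difference with the ethoxy chain in place.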